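Methoxy in Place of Methyl: An Expected Agonist Read-out

The source may hold more compounds than are shown below. What is called first, only, known or untested is meant among the compounds shown, and "the series" means these compounds.

Compound 1 `Cc1cccc(NC(=O)C(=O)Nc2ccc(OCC(=O)O)c(F)c2)c1` — 17.7%
Compound 2 `O=C(O)COc1ccc(NC(=O)Nc2ccccc2)cc1F` — 8.47%
Compound 3 `Cc1cccc(OCC(=O)Nc2ccc(OCC(=O)O)c(F)c2)c1` — 45.4%

Of the compounds shown here, three have been measured in a functional assay on CHO cells for agonist activity at Free fatty acid receptor 1 (Homo sapiens), read by FLIPR, tested at 100 nM; on this read-out higher numbers stand for a stronger effect at the one concentration tested and lower numbers for a weaker effect. Compound 3 stands highest of the three numbers: in this assay compound 3 gives 45.4%. The nearest of the other two is compound 1, which gives 17.7%, a number lower than that of compound 3 by more than the usual scatter. Furthest away is compound 2, which gives 8.47%, again lower by more than the scatter. Within the data shown here, none of these three pairs differs in only one place, so the numbers are compared as they stand and no single-change step can be drawn from them.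

Compound 4 `COc1cccc(OCC(=O)Nc2ccc(OCC(=O)O)c(F)c2)c1` is not yet measured. It differs from compound 3 in one place: methoxy in place of methyl on an aromatic carbon.

Among the measured compounds shown here, since no measured pair shows this kind of exchange, the size of the step in this assay can only be estimated. A small step is expected, either none beyond the scatter or a modest fall, and compound 4 is expected to give 40%, within 20% to 60%. The step from compound 3 to compound 4 is thus estimated at a number 5.4 percentage points lower from compound 3 to compound 4 (within the scatter).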

Compound 4, a percentage reported as activity, at one concentration (the size of the read-out at that concentration, not a potency): 31.7%
For compound 4 the middle estimate is 8.3 percentage points above the measured one, and the stated range covers the measured number.
By their numbers in this assay, from the lowest: compounds 2 and 1 (each within the scatter of the next); then compound 4; then compound 3.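

With compound 4 this position, on the six-membered aromatic ring of carbon only and meta to a large group, has its first single-change step: in this assay, methoxy in place of methyl reads as a number 13.7 percentage points lower from compound 3 to compound 4 (beyond the scatter) and so shows that the read-out is not indifferent to this exchange. Among these compounds, the change does not remove the effect at this one concentration, since compound 4 still gives 31.7% in this assay, but the earlier compounds, none of which differed in only one place, could not show even this much. Nothing at hand explains the step, which therefore stands as an observation without a cause.

Going by these compounds, the exchange adds both a heavy atom and a hydrogen-bond acceptor, and a single pair cannot separate the two, so it remains open how an ethyl group, a chlorine atom or a hydroxyl group would read at this place. On these data alone, it also remains open whether methoxy in place of methyl would give a similar step on the core of compound 1, or at another position on this ring.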